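A few compounds are considered here, and "the series" means these few. Any claim that something is new, unique, unknown or untested is made for them only; others in the source may bear on it.

Compound 1 `CCCOC(=O)C1=C(C)NC(=O)NC1c1ccoc1` and compound 2 `CC1=C(C(=O)OC(C)(C)C)C(c2ccoc2)NC(=O)N1` share a core, and compound 3 `CCCOC(=O)C1=C(C)NC(=S)NC1c1cccs1` sits on a core that differs from it; how the two cores differ is not broken down here. In an assay on membranes from HeLa cells for displacement of a labelled ligand from adenosine receptor A3 (Homo sapiens), read by scintillation counting, with a stated time of 180 min, tested at 1 uM (on this read-out lower numbers stand for less inhibition and higher numbers for more inhibition at the one concentration tested (going by the name of the read-out)), compound 1 gives 11%, compound 2 gives 2% and compound 3 gives 10%. The change from compound 1 to compound 2 is tert-butyl in place of propyl on an oxygen next to a carbonyl group, and its step is a number 9 percentage points lower from compound 1 to compound 2 (within the scatter). Compound 4 `CC1=C(C(=O)OC(C)(C)C)C(c2cccs2)NC(=S)N1` carries the same change made on compound 3, namely (tert-butyl in place of propyl on an oxygen next to a carbonyl group). Because compound 1 showed a step of a number 9 percentage points lower from compound 1 to compound 2 (within the scatter), the expected step from compound 3 to compound 4 is small as well, estimated as a number 6 percentage points lower from compound 3 to compound 4 (within the scatter). Compound 4 is therefore expected to give about 4% in this assay, most likely between -6% and 14%.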

Compound 4, a percentage reported as inhibition, at one concentration (the size of the read-out at that concentration, not a potency): 22%
Compound 4: middle estimate off by 18 percentage points, on the low side; the whole stated range lies below it.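

In this assay, replacing propyl with tert-butyl on an oxygen next to a carbonyl group gives a number 12 percentage points higher from compound 3 to compound 4 (beyond the scatter). In this series, the step seen on one core did not carry over to the other: the same change on two cores in this assay, a number 9 percentage points lower (within the scatter) from compound 1 to compound 2 and a number 12 percentage points higher (beyond the scatter) from compound 3 to compound 4, 21 percentage points apart, beyond the scatter of two such steps This rests on a single pair for each core, tested at one concentration, and it shows neither why the steps differ nor how the change would behave on a further core.

Which part of the difference between the two cores goes with this gap remains open. Also open, on these data alone, is how either core would respond to a longer chain, such as pentyl, on that oxygen, or to a carboxylic acid in place of the ester.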